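The source may hold more compounds than are shown below. What is called first, only, known or untested is meant among the compounds shown, and "the series" means these compounds.

Measured in a functional assay on K562 cells (Homo sapiens) for antiproliferative activity, read by MTT assay, with a stated time of 72 h; on this read-out higher numbers stand for weaker inhibition and lower numbers for stronger inhibition:
compound 1, `COc1cc(C(=O)c2sc3ccccc3c2-c2ccccc2)cc(OC)c1OC`: 2100 nM
compound 2, `COc1cc(C(=O)c2sc3ccccc3c2-c2ccc(F)cc2)cc(OC)c1OC`: 2100 nM
compound 3, `COc1ccc(-c2c(C(=O)c3cc(OC)c(OC)c(OC)c3)sc3ccccc23)cc1`: 1700 nM

Compound 1 is level with compound 2, and the number for compound 3 lies within the usual scatter of both, so none of the three can be set apart from the others. The step to compound 4, `COc1ccccc1-c1c(C(=O)c2cc(OC)c(OC)c(OC)c2)sc2ccccc12`, is methoxy in place of hydrogen on an aromatic carbon. Going by the values given here, one measured step bears on it directly: the same change, methoxy in place of hydrogen on an aromatic carbon, though at another place on the same ring, gave a 1.2-fold lower number from compound 1 to compound 3 (0.09 log units; within the scatter). The other change on that ring, fluoro in place of hydrogen, gave no change at the digits printed from compound 1 to compound 2 (within the scatter). Neither alteration of this ring moved the number beyond the scatter, so for compound 4 no step beyond the scatter is expected in either direction, and the expected step is a 1.1-fold lower number from compound 1 to compound 4 (0.02 log units; within the scatter). Compound 4 is therefore estimated at 2000 nM, with a range from 900 nM to 4500 nM.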

Compound 4, half-maximal inhibitory concentration: 3400 nM
Compound 4: middle estimate off by 1.7-fold (0.23 log units), on the low side; the range from low to high includes it.
By their numbers in this assay, from the lowest: compounds 3, 1, 2 and 4 (each within the scatter of the next).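

In this assay, methoxy on an aromatic carbon ortho to a large group gives a 1.6-fold higher number from compound 1 to compound 4 (0.21 log units; within the scatter) and so, at this position too, the change stays inside the scatter. Shifting the methoxy, with 2-methoxyphenyl in place of 4-methoxyphenyl, gives a 2.0-fold higher number from compound 3 to compound 4 (0.30 log units; within the scatter) and this is the largest gap among the four compounds, yet it still does not set them apart. Replacing 4-fluorophenyl with 2-methoxyphenyl gives a 1.6-fold higher number from compound 2 to compound 4 (0.21 log units; within the scatter) and adds the same message: three different substitutions on this ring have not taken the number beyond the scatter.

From the compounds shown here alone, whether an amine or a carboxylic acid on this ring would do so remains open. Nothing measured here explains these small steps.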